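This account rests on a few compounds, and the source may have more. Where it says the series, first, only, none or still open, it means among the compounds named here.

In an ADME assay for permeability, using PAMPA, with a stated time of 4 h (a higher number here means that the compound crosses the layer faster, a lower number that the compound crosses the layer more slowly), three compounds have been measured:

compound 1 `Cn1c(COc2cccc(C(=O)O)c2)nc2ccc(Oc3cccc(Cl)n3)cc21` (7.6 10^-6 cm/s)
compound 2 `Cn1c(COc2cccc(C(=O)O)c2)nc2ccc(Oc3ccc(Cl)cn3)cc21` (16.2 10^-6 cm/s)
compound 3 `Cn1c(COc2cccc(C(=O)O)c2)nc2ccc(Oc3ccc(F)cn3)cc21` (4.7 10^-6 cm/s)

Compound 3 (4.7 10^-6 cm/s) sits close to one neighbour and well short of the other. The two steps that place it are a 1.6-fold lower number from compound 1 to compound 3 (0.21 log units; within the scatter) and a 3.4-fold lower number from compound 2 to compound 3 (0.54 log units; beyond the scatter).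

Compound 4 `Cc1cnc(Oc2ccc3nc(COc4cccc(C(=O)O)c4)n(C)c3c2)c(F)c1` is still unmeasured. Its structure differs at one place: 3-fluoro-5-methylpyridin-2-yl in place of 5-fluoropyridin-2-yl on an oxygen on an aromatic ring. In words, this is 3-fluoro-5-methylpyridin-2-yl in place of 5-fluoropyridin-2-yl on an oxygen on an aromatic ring.

Among the measured compounds shown here, no measured step covers this exchange. The nearest guides are changes to the same substituent, namely a 2.1-fold higher number from compound 1 to compound 2 (0.33 log units; beyond the scatter) and again a 3.4-fold lower number from compound 2 to compound 3 (0.54 log units; beyond the scatter). Both are modest, and they show that such changes can move the number either way. None of them involves a methyl group, so the direction remains uncertain, and only a slight rise is expected. The expected step is a 1.5-fold higher number from compound 3 to compound 4 (0.17 log units; within the scatter). The estimate for compound 4 is 7 10^-6 cm/s, with an expected range from 3 10^-6 cm/s to 16 10^-6 cm/s.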

Compound 4, apparent permeability: 5.8 10^-6 cm/s
For compound 4 the middle estimate is 1.2-fold (0.08 log units) above the measured one; the measured number falls inside the stated range.
By their numbers in this assay, from the lowest: compounds 3, 4 and 1 (each within the scatter of the next); then compound 2.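

In this assay, 3-fluoro-5-methylpyridin-2-yl in place of 5-fluoropyridin-2-yl on the oxygen gives a 1.2-fold higher number from compound 3 to compound 4 (0.09 log units; within the scatter), so this first exchange to bring in a methyl group stays within the scatter. The same group is separated only from the 5-chloropyridin-2-yl, with a 2.8-fold lower number from compound 2 to compound 4 (0.45 log units; beyond the scatter), while against the 6-chloropyridin-2-yl the step is a 1.3-fold lower number from compound 1 to compound 4 (0.12 log units; within the scatter), so at this position only the 5-chloropyridin-2-yl of compound 2 stands apart. Nothing measured here accounts for these steps.

The compounds shown do not separate the fluoro from the methyl within the entering group, as the two come in together. As far as these compounds go, how a 5-methoxypyridin-2-yl group on the same oxygen, or an amide in place of the carboxylic acid, would read in this assay also stays open.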